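Diethyl for dimethyl on two acylsemicarbazone cores

A few compounds are considered here, and "the series" means these few. Any claim that something is new, unique, unknown or untested is made for them only; others in the source may bear on it.

The study compares two acylsemicarbazone-type amines that differ only in the dialkylamino group carried on a benzylic carbon. Compound 1 `CN(C)Cc1ccc2nc(NC(=O)N/N=C/c3ccccn3)sc2c1` carries a dimethylamino group on the saturated chain carbon bound to an aromatic carbon of its core. In a functional assay on MCF7 cells (Homo sapiens) for antiproliferative activity, read by CCK-8 assay, with a stated time of 24 h (on this read-out higher numbers stand for weaker inhibition and lower numbers for stronger inhibition), compound 1 gives only a limit, > 40000 nM. Compound 2 `CCN(CC)Cc1ccc2nc(NC(=O)N/N=C/c3ccccn3)sc2c1` is the diethyl analogue, obtained through (diethylamino in place of dimethylamino on a saturated chain carbon bound to an aromatic carbon). In this assay compound 2 also reaches only a limit, > 40000 nM. The step that the two limits leave unreadable from compound 1 to compound 2 is therefore of unreadable size, since both ends sit at the same limit.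

Compound 3 `CN(C)Cc1ccc(NC(=O)NN=C(c2ccccn2)c2ccccn2)cc1` is built on a different core, and the difference between the two cores is not broken down here. In this assay compound 3 likewise gives only a limit, > 40000 nM. Compound 4 `CCN(CC)Cc1ccc(NC(=O)NN=C(c2ccccn2)c2ccccn2)cc1` is the corresponding diethyl analogue of compound 3, made by diethylamino in place of dimethylamino on a saturated chain carbon bound to an aromatic carbon, the same change as that from compound 1 to compound 2, at the same place.

Across the three measured compounds the limit of > 40000 nM in this assay, at which 3 of the 3 values shown sit, is the only evidence on this change, and it gives no readable size. Compound 4 is expected to behave as its neighbours do, with an estimated step that the limit leaves unreadable from compound 3 to compound 4 that cannot be read against the limit. The estimate for compound 4 is 60000 nM, with a range from 30000 nM to 200000 nM, and most likely the assay would again report only a limit for compound 4.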

Compound 4, half-maximal inhibitory concentration: > 40000 nM
Compound 4 ended at the assay's limit; the forecaster's own chance of this, stated with the estimate: 85%; the middle value lies beyond the limit too.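

In this assay compound 3 and compound 4 both stand only at a limit, so the step between them cannot be read and the change from dimethylamino to diethylamino gains no readable size. The compounds shown leave open how strongly any of them inhibits in this assay, and whether diethylamino differs from dimethylamino there at all, with one limit as the only evidence: the limit of > 40000 nM in this assay, at which 4 of the 4 values shown sit.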